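The source may report more compounds than this note shows. Statements on the series, on what has been measured and on what is new or still open speak of the compounds shown alone.

Three compounds sit on a common core, each carrying a carboxyphenyl end joined through a four-carbon chain. Compound 1 (`Cc1c(OCCCCOc2cccc(C(=O)O)c2)ccc(C(=O)CC(C)C)c1C`) gives 106% in an ADME assay on a cell-free system (plasma, Rattus norvegicus) for metabolic stability, read by LC-MS, with a stated time of 60 min, tested at 100 uM; on this read-out lower numbers stand for a less stable compound and higher numbers for a more stable compound. Compound 2 (`Cc1c(OCCCCOc2cccc(C(=O)O)c2)ccc(C(=O)CC(C)C)c1O`) gives 100% in this assay, and compound 3 (`Cc1c(OCCCCOc2cccc(C(=O)O)c2)ccc(C(=O)CC2CCCC2)c1O`) gives 99%. The value of compound 2 is flanked by those of the other two: a number 6 percentage points lower from compound 1 to compound 2 (within the scatter), and a number 1 percentage points lower from compound 2 to compound 3 (within the scatter), so all three sit together inside the scatter.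

Compound 4 (`Cc1c(OCCCCOc2ccc(F)c(C(=O)O)c2)ccc(C(=O)CC(C)C)c1O`) departs from compound 2 by fluoro in place of hydrogen on an aromatic carbon. Neither measured step touches the carboxyphenyl end of the molecule: one altered a substituent on the core, the other the chain at the carbonyl, and both stayed inside the scatter. No measured change bears directly on the ring that is modified here, but every change made so far in this series left the read-out in this assay essentially unmoved. Compound 4 is therefore expected to show no change at the digits printed from compound 2 to compound 4 (within the scatter), nothing beyond the scatter. The estimate for compound 4 is 100%, with a range from 90% to 110%.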

Compound 4, percent of the compound remaining: 101%
For compound 4 the middle estimate is 1 percentage points below the measured one; the measured number falls inside the stated range.
By their numbers in this assay, from the lowest: compounds 3, 2, 4 and 1 (each within the scatter of the next).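

The earlier steps shown here changed the core and the chain at the carbonyl, whereas this one reaches the carboxyphenyl end, turning 3-carboxyphenyl into 3-carboxy-4-fluorophenyl. In this assay, the read-out gives a number 1 percentage points higher from compound 2 to compound 4 (within the scatter), so a fluoro ortho to a carboxy group does not separate the two compounds on this measure. The data shown offer no explanation for this result.

As far as these compounds go, whether chloro, methoxy or an amine at this place would also stay within the scatter of compound 2 remains open. All the compounds shown also keep the carboxylic acid and the same linking chain, so the effect of an amide or a tetrazole in place of the acid, or of a longer chain, is still unknown.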